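One Extra Carbon, Two Different Places

A few compounds are considered here, and "the series" means these few. Any claim that something is new, unique, unknown or untested is made for them only; others in the source may bear on it.

Compound 1, `CNc1nc(NCc2ccccc2)nc(-c2ccccc2CO)n1`: 4.51 in a functional assay on cells for positive allosteric modulation of G-protein coupled receptor 68 (Homo sapiens), read by a luciferase reporter and cAMP accumulation, with a stated time of 30 min, at pH 6.8 and pH 8.3, in the presence of a further agent that is not named here; a higher number here means a more potent compound, by a factor of ten per unit of this negative logarithm, a lower number a less potent compound
Compound 2, `CCNc1nc(NCc2ccccc2)nc(-c2ccccc2CO)n1`: 4.63 in this assay
Compound 3, `CCOc1ccc(-c2nc(N)nc(NCc3ccccc3)n2)c(CO)c1`: 4.37 in this assay

Compound 1 and compound 2 share one core, while compound 3 rests on a different one; the difference between the two cores is not broken down here. Among the compounds with values here, the only change from compound 1 to compound 2 is methyl in place of hydrogen on a saturated chain carbon bound to a nitrogen on an aromatic ring. In this assay that change produced a number 0.12 log units higher from compound 1 to compound 2 (within the scatter), so the two compounds cannot be told apart by this measurement. Compound 3 likewise gives a number that sits within the scatter of both compound 1 and compound 2, so none of the three can be called stronger or weaker than another.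

Compound 4, `CC(C)Oc1ccc(-c2nc(N)nc(NCc3ccccc3)n2)c(CO)c1`, has not yet been measured. It differs from compound 3 by methyl in place of hydrogen on a saturated chain carbon bound to an oxygen on an aromatic ring and a saturated chain carbon. Within the data shown here, this is the same kind of change as the one from compound 1 to compound 2, but not the same: there the carbon gaining the methyl is bound to a nitrogen on an aromatic ring, here it is bound to an oxygen on an aromatic ring and a saturated chain carbon.

Because the earlier step of a number 0.12 log units higher from compound 1 to compound 2 (within the scatter) stayed within the scatter, compound 4 is expected to move from compound 3 by only a number 0.08 log units higher from compound 3 to compound 4 (within the scatter) in this assay. Compound 4 is therefore estimated at 4.45, with a likely range from 4 to 4.9.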

Compound 4, negative logarithm of the antagonist equilibrium constant: 4.91
Compound 4: middle estimate off by 0.46 log units, on the low side; the measured number lies above the stated range.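

In this assay, the extra methyl that turns ethoxy into isopropoxy gives a number 0.54 log units higher from compound 3 to compound 4 (beyond the scatter) and so, on this core, separates the two compounds by more than repeat measurements would be expected to. The earlier step on the other core stayed within the scatter, which makes it tempting to say that the same change works on one core and not on the other, but the comparison of the two steps does not support that: the same change on two cores in this assay, a number 0.12 log units higher (within the scatter) from compound 1 to compound 2 and a number 0.54 log units higher (beyond the scatter) from compound 3 to compound 4, 0.42 log units apart, within the scatter of two such steps

So the data do not show that the core, or the different atom carrying the new methyl, alters what this extra carbon does, and they do not show that its effect carries over unchanged either, with only one pair of compounds on each core to go on.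

Still open, on these data alone, is whether the number keeps climbing with a larger group in the same place, such as tert-butoxy or cyclopentyloxy, or falls back with a longer straight chain such as butoxy. Also open, as far as these compounds go, is whether an isopropyl group on the amine nitrogen of the core of compound 1 would give a clearer step than the ethyl group of compound 2.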